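Furan-to-styryl swap on the octadecyl amide: expectation

This account rests on a few compounds, and the source may have more. Where it says the series, first, only, none or still open, it means among the compounds named here.

Measured in a functional assay on HepG2 cells (Homo sapiens) for cytotoxicity, read by MTT assay, with a stated time of 48 h (a lower number here means a stronger inhibitor, a higher number a weaker inhibitor), so far:
- compound 1, `CCCCCCCCCCCCNC(=O)[C@@H](NC(=O)c1ccco1)[C@@H](C)O`, 147000 nM
- compound 2, `CCCCCCCCCCCCNC(=O)[C@@H](NC(=O)/C=C/c1ccccc1)[C@@H](C)O`, a limit of the assay, > 200000 nM
- compound 3, `CCCCCCCCCCCCCCCCCCNC(=O)[C@@H](NC(=O)c1ccco1)[C@@H](C)O`, 42300 nM

Compound 3 holds the lowest number of the two measured; compound 1 sits a 3.5-fold lower number from compound 1 to compound 3 (0.54 log units; beyond the scatter). Compound 4, `CCCCCCCCCCCCCCCCCCNC(=O)[C@@H](NC(=O)/C=C/c1ccccc1)[C@@H](C)O`, is not yet measured in this assay. It differs from compound 3 by 2-phenylethenyl in place of furan-2-yl on a carbonyl carbon. Among the compounds with values here, the one measured step that bears on this change is an at least 1.3-fold higher number from compound 1 to compound 2 (0.13 log units; that floor lies within the scatter), which is only a floor, fixed by the limit of > 200000 nM in this assay, at which 1 of the 3 values shown sits. On that basis a higher number is expected for compound 4, of uncertain size, and it may itself end at the limit. Compound 4 is estimated at 100000 nM, within 45000 nM to 200000 nM, an expected step of a 2.4-fold higher number from compound 3 to compound 4 (0.37 log units; beyond the scatter).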

Compound 4, half-maximal inhibitory concentration: 128000 nM
Estimate against measurement, compound 4: 1.3-fold (0.11 log units) below; the range from low to high includes it.
By their numbers in this assay, from the lowest: compound 3; then compounds 4 and 1 (each within the scatter of the next). At a limit, above all of these: compound 2.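

With the core of compound 3, 2-phenylethenyl in place of furan-2-yl on a carbonyl carbon now has a readable size, a 3.0-fold higher number from compound 3 to compound 4 (0.48 log units; beyond the scatter), where the shorter chain gave only a floor: the same change on two cores in this assay, an at least 1.3-fold higher number (0.13 log units; that floor lies within the scatter) from compound 1 to compound 2 and a 3.0-fold higher number (0.48 log units; beyond the scatter) from compound 3 to compound 4; the limit leaves it open whether they differ.
With 2-phenylethenyl kept, hexyl in place of hydrogen on a saturated chain carbon gives an at least 1.5-fold lower number from compound 2 to compound 4 (0.19 log units; that floor lies within the scatter), again only a floor: the same change on two cores in this assay, a 3.5-fold lower number (0.54 log units; beyond the scatter) from compound 1 to compound 3 and an at least 1.5-fold lower number (0.19 log units; that floor lies within the scatter) from compound 2 to compound 4; the limit leaves it open whether they differ.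
Compound 2 remains a limit of the assay, > 200000 nM.

Open, on these data alone, is how an amine or a carboxylic acid in place of furan-2-yl on the carbonyl carbon would read, and whether a chain longer than that of compound 3 would lower the number further.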